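The compounds below may be only part of what the source reports. "The series", "measured", "known", "first", "only" and "open" are said of these compounds alone.

Working notes on a short series read in a functional assay (muscle tissue) with Cavia porcellus as the target; a higher number here means that more compound is needed for the effect, a lower number that less compound is needed. Compound 1 (`COC(=O)C1=C(C)NC(C)=C(C(=O)OC)C1c1ccccc1`) gives 28.2 nM, and compound 2 (`COC(=O)C1=C(C)N=C(C)/C(=C(\O)OC)C1c1ccc(F)cc1`) gives 129 nM. Among the compounds with values here, compound 2 thus holds the higher of the only two numbers available, so more of it is needed for the effect, and its gap to compound 1 lies beyond the scatter. Within the data shown here, two values do not make a trend, and no measured step in one place exists to calibrate a change of substituent.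

The next entry is compound 3 (`COC(=O)C1=C(C)N=C(C)/C(=C(\O)OC)C1c1cccc(Br)c1`). The change from compound 2 is 3-bromophenyl in place of 4-fluorophenyl on a saturated ring carbon, with 3-bromophenyl in place of 4-fluorophenyl on a saturated ring carbon. The rest of the structure stays the same. The only other reference point is compound 1 at 28.2 nM, so a move in this assay towards that lower number seems more likely than a further rise, although this rests on one value. The expected step, with wide uncertainty, is a 3.7-fold lower number from compound 2 to compound 3 (0.57 log units; beyond the scatter). Compound 3 is estimated at 35 nM, with an expected range of 8 nM to 150 nM.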

Compound 3, half-maximal effective concentration: 1.29 nM
Estimate against measurement, compound 3: 27-fold (1.43 log units) above; measured number below the stated range.
By their numbers in this assay, from the lowest: compound 3; then compound 1; then compound 2.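

In this assay the aryl group on the saturated ring carbon now stands out as a place of high leverage: 3-bromophenyl in place of 4-fluorophenyl gives a 100-fold lower number from compound 2 to compound 3 (2.00 log units; beyond the scatter) with the rest of the structure unchanged. The two groups match in heavy-atom count, in their single six-membered aromatic ring of carbon only and in their hydrogen-bond donor and acceptor counts, so a large step at this place arises without any difference in these counts. No measured data accompany the step to account for its size.

The halogen and its place on the phenyl ring change together in this one step, so the compounds shown do not separate the effect of bromine from that of its placement, and a 3-fluorophenyl or 4-bromophenyl group at the same ring carbon would be needed to tell the two apart. Also open, going by these compounds, is how a phenyl ring carrying an amine or a carboxylic acid would read in this assay at this place.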